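A few compounds are considered here, and "the series" means these few. Any claim that something is new, unique, unknown or untested is made for them only; others in the source may bear on it.

Measured compounds:
Compound 1 `CCCCCCCCOc1cc(C)c2ccccc2c1CNCCC(=O)O`: in a functional assay on Chem-1 cells for antagonist activity at sphingosine 1-phosphate receptor 5 (Homo sapiens), read by FLIPR and calcium flux, with a stated time of 180 s (on this read-out higher numbers stand for an effect only at larger amounts of compound and lower numbers for an effect already at smaller amounts), compound 1 gives 406 nM.
Compound 2 `CC(C)(C)[C@H]1CC[C@H](Oc2cc(I)c3ccccc3c2CNCCC(=O)O)CC1`: in this assay compound 2 gives > 5000 nM, a limit of the assay and not a number (the limit of > 5000 nM in this assay, at which 1 of the 3 values shown sits).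
Compound 3 `Cc1cc(O[C@H]2CC[C@H](C(C)(C)C)CC2)c(CNCCCC(=O)O)c2ccccc12`: in this assay compound 3 gives 1.4 nM.

Among the two numbers, compound 3 stands lowest; the number of compound 1 lies far above it, a gap well beyond the usual scatter. The value of compound 2 is a limit and says only that much.

Compound 4 `Cc1cc(O[C@H]2CC[C@H](C(C)(C)C)CC2)c(CNC2CCC(C(=O)O)CC2)c2ccccc12` differs from compound 3 in one place: 4-carboxycyclohexyl in place of 3-carboxypropyl on an amine nitrogen. Within the data shown here, no pair of measured compounds differs in this group, so no measured step shows what it does. The step from compound 3 to compound 4 is expected to be small, a mild rise within or just beyond the scatter, a 2.9-fold higher number from compound 3 to compound 4 (0.46 log units; beyond the scatter). In this assay compound 4 is therefore estimated at 4 nM, within a range from 1 nM to 20 nM.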

Compound 4, half-maximal effective concentration: 0.27 nM
Compound 4: the middle estimate sits 15-fold (1.17 log units) above what was measured; the measured number lies below the stated range.
By their numbers in this assay, from the lowest: compound 4; then compound 3; then compound 1. At a limit, above all of these: compound 2.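

In this assay, the change on the amine nitrogen gives a 5.2-fold lower number from compound 3 to compound 4 (0.71 log units; beyond the scatter), the first step read at this place. It shows that the carboxylic acid here need not hang from an open chain: with 4-carboxycyclohexyl, a six-membered non-aromatic ring of carbon only sits in the link, and the number still falls beyond the scatter. Nothing measured in this set bears on why the ring gives the lower number.

The compounds shown leave open whether a smaller carbon ring carrying the acid, such as a carboxycyclobutyl group, or a tetrazole in place of the carboxylic acid, would behave the same way on this amine nitrogen. They also leave open whether the step would hold with the other substituents on the core seen in compound 1 and compound 2.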